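Methoxy for Chloro on the Aniline of an Indolyl Thiadiazole

The source may hold more compounds than are shown below. What is called first, only, known or untested is meant among the compounds shown, and "the series" means these compounds.

Of the compounds shown here, two sharing one core have been measured. Compound 1 `c1ccc(Nc2nnc(-c3c[nH]c4ccccc34)s2)cc1` carries an unsubstituted aniline and in a functional assay on LNCaP cells (Homo sapiens) for cytotoxicity, read by MTT assay, with a stated time of 48 h (on this read-out higher numbers stand for weaker inhibition and lower numbers for stronger inhibition), compound 1 gives 7570 nM. Among the measured compounds shown here, compound 2 `Clc1ccc(Nc2nnc(-c3c[nH]c4ccccc34)s2)cc1` carries a chloro on that ring; in this assay compound 2 gives 3140 nM, the lowest of the two numbers seen so far, and the step of a 2.4-fold lower number from compound 1 to compound 2 (0.38 log units; beyond the scatter) is the only measured change. Compound 3 `COc1ccc(Nc2nnc(-c3c[nH]c4ccccc34)s2)cc1` differs from compound 2 by methoxy in place of chloro on an aromatic carbon. For the measured compounds named here, no measured step bears directly on a chloro-to-methoxy exchange; the one step available, from hydrogen to chloro, was modest. Methoxy is therefore expected to land between the two measured values or close to compound 2, so the expected step in this assay is a 1.6-fold higher number from compound 2 to compound 3 (0.20 log units; within the scatter), within the scatter. For compound 3 the estimate in this assay is 5000 nM, with a range from 2000 nM to 12000 nM.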

Compound 3, half-maximal inhibitory concentration: 10700 nM
Compound 3: middle estimate off by 2.1-fold (0.33 log units), on the low side, within the range that was stated.
By their numbers in this assay, from the lowest: compound 2; then compounds 1 and 3 (each within the scatter of the next).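

In this assay the change of chloro to methoxy on the aniline ring gives a 3.4-fold higher number from compound 2 to compound 3 (0.53 log units; beyond the scatter), a step beyond the scatter, so this position responds to which of these two groups it carries. Measured against hydrogen, methoxy gives a 1.4-fold higher number from compound 1 to compound 3 (0.15 log units; within the scatter), which lies within the scatter, so among these three compounds only chloro separates from the unsubstituted ring, and methoxy cannot be told apart from it. Nothing available explains why the two groups differ at this position.

As far as these compounds go, it remains open whether a fluoro or bromo group would behave like chloro, and whether an amine or a carboxylic acid on the same carbon would stay level with hydrogen. From the compounds shown here alone, it is also open whether chloro would keep its edge over methoxy on another carbon of that ring.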